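Three Aryl Variants on the Shared Core and a Fourth

The compounds below may be only part of what the source reports. "The series", "measured", "known", "first", "only" and "open" are said of these compounds alone.

Compound 3 `Cn1ncc2c(NC(=O)NCc3cc(C(F)(F)F)nn3-c3ccc(C(C)(C)C)cc3)cccc21` gives 13.2 nM in an assay on CHO-K1 cells for antagonist activity at transient receptor potential cation channel subfamily V member 1 (Homo sapiens), read by FLIPR and calcium flux, with a stated time of 6 min (on this read-out higher numbers stand for weaker inhibition and lower numbers for stronger inhibition), and so carries the highest of the three numbers measured, though each of the other two lies within the scatter of it. Compound 1 `Cn1ncc2c(NC(=O)NCc3cc(C(F)(F)F)nn3-c3cccc(F)c3)cccc21` gives 7 nM in this assay, and compound 2 `Cn1ncc2c(NC(=O)NCc3cc(C(F)(F)F)nn3-c3ccc(F)cc3)cccc21` gives 8.4 nM. The step of a 1.2-fold higher number from compound 1 to compound 2 (0.08 log units; within the scatter) and the step of a 1.9-fold higher number from compound 1 to compound 3 (0.28 log units; within the scatter) both stay within the scatter, as does the step of a 1.6-fold higher number from compound 2 to compound 3 (0.20 log units; within the scatter).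

Compound 4 `Cc1ccc(-n2nc(C(F)(F)F)cc2CNC(=O)Nc2cccc3c2cnn3C)cc1C` has not yet been measured. Its difference from compound 3 is 3,4-dimethylphenyl in place of 4-(tert-butyl)phenyl on an aromatic nitrogen. The step that bears most directly on this exchange is a 1.6-fold higher number from compound 2 to compound 3 (0.20 log units; within the scatter), where a fluoro and a tert-butyl on the same aromatic carbon gave numbers indistinguishable within the scatter; the steps from compound 1 to compound 2 and from compound 1 to compound 3 point the same way, with nothing beyond the scatter among any of the aryl groups tried. On that basis no step beyond the scatter is expected in this assay, and the estimated step of a 1.2-fold lower number from compound 3 to compound 4 (0.08 log units; within the scatter) is small. Compound 4 is therefore expected to give about 11 nM in this assay, within a range from 5 nM to 25 nM.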

Compound 4, inhibition constant: 3.5 nM
For compound 4 the middle estimate is 3.1-fold (0.50 log units) above the measured one; the whole stated range lies above it.
By their numbers in this assay, from the lowest: compounds 4, 1, 2 and 3 (each within the scatter of the next, the first and the last beyond it).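

Across compounds 1, 2 and 3 the aryl group on the aromatic nitrogen seemed to make no difference that could be told from the scatter, but 3,4-dimethylphenyl shows that this position can respond: in this assay its exchange for 4-(tert-butyl)phenyl gives a 3.8-fold lower number from compound 3 to compound 4 (0.58 log units; beyond the scatter) and its exchange for 4-fluorophenyl gives a 2.4-fold lower number from compound 2 to compound 4 (0.38 log units; beyond the scatter), both of them modest steps. The response does not separate 3,4-dimethylphenyl from every earlier group, since its exchange for 3-fluorophenyl gives a 2.0-fold lower number from compound 1 to compound 4 (0.30 log units; within the scatter) and so leaves compound 4 and compound 1 indistinguishable in this read-out. Nothing among the data shown accounts for the change, and the reason for these steps remains unknown.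

The compounds shown leave open whether both methyl groups of compound 4 are needed or a phenyl ring bearing a single methyl would give the same number. They also leave open how this position would take a phenyl ring carrying a methoxy group, an amine or a carboxylic acid, or a pyridine ring in place of the phenyl ring.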